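From Fluoro to Methyl: What Compound 3 May Show

The source may report more compounds than this note shows. Statements on the series, on what has been measured and on what is new or still open speak of the compounds shown alone.

Compound 1: `Nc1nc(NCCNc2ncc(-c3ncc[nH]3)c(-c3ccc(C(F)(F)F)cc3)n2)ccc1[N+](=O)[O-]`; in an ADME assay on microsomes from liver (Rattus norvegicus) for metabolic stability (a higher number here means that the compound lasts longer, a lower number that the compound disappears faster), compound 1 gives > 0.5 h, which is a limit of the assay and not a number.
Compound 2: `Nc1nc(NCCNc2ncc(-c3ncc[nH]3)c(-c3ccc(F)cc3Br)n2)ccc1[N+](=O)[O-]`; in this assay compound 2 gives > 0.5 h, likewise a limit of the assay rather than a number.

Compound 2 therefore stands at the limit of > 0.5 h in this assay, at which 2 of the 2 values shown sit, and the step that the two limits leave unreadable from compound 1 to compound 2 cannot be read from two limits. Compound 3 `Cc1ccc(-c2nc(NCCNc3ccc([N+](=O)[O-])c(N)n3)ncc2-c2ncc[nH]2)c(Br)c1` differs from compound 2 by methyl in place of fluoro on an aromatic carbon. No measured step bears on this change in a readable way, since the only step shown is hidden by the limits. Because both values sit at the limit of > 0.5 h in this assay, at which 2 of the 2 values shown sit, any expectation for compound 3 rests on the change alone, and a step that the limit leaves unreadable from compound 2 to compound 3 within the scatter in this assay is expected, in no particular direction. Compound 3 is estimated at 0.8 h in this assay, with a range from 0.4 h to 2 h.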

Compound 3, half-life: > 0.5 h
Compound 3: a limit, no number; the forecaster's own chance of this, stated with the estimate: 60%; the middle value is on the limit's open side.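

In this assay compound 3 gives > 0.5 h, again a limit of the assay and not a number. For the compounds shown here, no step among compound 1, compound 2 and compound 3 can be read, because all three share one limit: the limit of > 0.5 h in this assay, at which 3 of the 3 values shown sit. The compounds shown leave open what half-life any of them actually has, and so whether methyl in place of fluoro makes any difference.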